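Inverting one ring stereocentre in a series of acid inhibitors

The compounds below may be only part of what the source reports. "The series", "measured", "known", "first", "only" and "open" are said of these compounds alone.

Measured compounds:
- Compound 1, `CCCc1c(OCCCOc2ccc(C(N)=O)c(OC)c2CCC)ccc2c1OC(C(=O)O)CC2`: 2.7 nM
- Compound 2, `CCCc1c(OCCCOc2ccc(C(=O)NC)c(OC)c2CC2CC2)ccc2c1O[C@@H](CCC(=O)O)CC2`: 10.7 nM

Both compounds were tested in a functional assay for inhibition, with Homo sapiens as the target; a lower number here means a stronger inhibitor, a higher number a weaker inhibitor. Compound 1 gives 2.7 nM in this assay, the lower of the two numbers. Compound 2 gives 10.7 nM, the higher of the two; its gap to compound 1 lies beyond the usual scatter, so compound 2 is the weaker inhibitor of the pair. Compound 1 and compound 2 differ in several places at once, so the two numbers say nothing about any single change.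

Compound 3, `CCCc1c(OCCCOc2ccc(C(=O)NC)c(OC)c2CC2CC2)ccc2c1O[C@H](CCC(=O)O)CC2`, has not yet been measured. Its relation to compound 2 is narrow: the two compounds have the same atoms and bonds and differ only in configuration as drawn: 1 of 1 stereo elements differ; a stereocentre at a saturated ring carbon is drawn R in compound 2 and S in compound 3. Going by the values given here, no measured pair shows what such an inversion does here, so the direction of the step is open. Mirror-image pairs of this kind often differ widely in this assay, and either direction is possible. The expected step of a 1.4-fold higher number from compound 2 to compound 3 (0.15 log units; within the scatter) is therefore set near no change but with a wide range. Compound 3 is estimated at 15 nM, between 1.5 nM and 150 nM.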

Compound 3, half-maximal inhibitory concentration: 24.4 nM
The estimate for compound 3 lay 1.6-fold (0.21 log units) below the measured number; the range from low to high includes it.
By their numbers in this assay, from the lowest: compound 1; then compound 2; then compound 3.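

Drawing the stereocentre at the saturated ring carbon as S instead of R gives a 2.3-fold higher number from compound 2 to compound 3 (0.36 log units; beyond the scatter) in this assay, so the R form is the stronger inhibitor of this mirror-image pair, although the step is modest. Going by these compounds alone, this is the first clean reading at this position, since compound 1 and compound 2 differ in several places at once and their numbers could not be tied to any single change. The step can be assigned to this one stereocentre, with no other structural change involved, because the comparison rests on a single structural fact: the fact that compounds 2 and 3 differ only in the configuration as drawn.

One inverted pair, carrying one side chain and one set of substituents, cannot show whether the preference for R is general across the series, and the stereocentre of compound 1 is drawn without any configuration, so it adds nothing on this point. Going by these compounds, it also remains open whether the inversion would have the same direction and size with a tetrazole in place of the carboxylic acid, or with a longer chain carrying the acid.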